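The source may report more compounds than this note shows. Statements on the series, on what has been measured and on what is new or still open speak of the compounds shown alone.

In a functional assay on NALM-6 cells (Homo sapiens) for cytotoxicity, read by MTT assay (a higher number here means a weaker inhibitor, a lower number a stronger inhibitor), compound 1 (`O=C(/C=C/c1ccc(Cl)cc1)c1ccccc1O`) gives 9300 nM and compound 2 (`O=C(/C=C/c1ccc(Br)cc1)c1ccccc1O`) gives 6800 nM. Going by the values given here, these are the only two numbers so far, and they lie within the scatter of each other, leaving compound 2 level with compound 1. The next structure, compound 3 (`O=C(/C=C/c1ccc([N+](=O)[O-])cc1)c1ccccc1O`), has nitro in place of bromo on an aromatic carbon, para to a large group: nitro in place of bromo on an aromatic carbon. Among the compounds with values here, the single measured step, a 1.4-fold lower number from compound 1 to compound 2 (0.14 log units; within the scatter), exchanges one halogen for another. Within the data shown here, it bears only loosely on this change, and no measured compound carries a nitro group. The data therefore give no direction, and no shift beyond the scatter is expected in this assay, though with wide uncertainty. The expected step is a 1.1-fold higher number from compound 2 to compound 3 (0.04 log units; within the scatter). The estimated value for compound 3 is 7500 nM, with an expected range from 2500 nM to 22000 nM.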

Compound 3, half-maximal inhibitory concentration: 6900 nM
For compound 3 the middle estimate is 1.1-fold (0.04 log units) above the measured one, and the stated range covers the measured number.
By their numbers in this assay, from the lowest: compounds 2, 3 and 1 (each within the scatter of the next).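

Going by these compounds alone, at this position on the aromatic ring, para to a large group, the earlier compounds showed only one halogen exchanged for another. Compound 3 extends this to a group that is not a halogen: nitro brings 3 heavy atoms and 2 hydrogen-bond acceptors where bromo has a single atom and none, yet this assay shows a 1.0-fold higher number from compound 2 to compound 3 (0.01 log units; within the scatter) and a 1.3-fold lower number from compound 1 to compound 3 (0.13 log units; within the scatter), both within the scatter. Chloro, bromo and nitro thus stand level at this position in this assay, and nothing measured here explains that.

From the compounds shown here alone, whether an amine, a carboxylic acid or a methoxy group at this position would move the number beyond the scatter remains open. So does the effect of a change elsewhere on the shared core.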